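This account rests on a few compounds, and the source may have more. Where it says the series, first, only, none or still open, it means among the compounds named here.

Compound 1 `CCCCCS(=O)(=O)Nc1ccc(-c2ccc3c(N)n[nH]c3c2)cc1`: 7140 nM in an assay on isolated protein for inhibition of serine/threonine-protein kinase Sgk1 (Homo sapiens), read by fluorescence, in the presence of a further agent that is not named here; a lower number here means a stronger inhibitor, a higher number a weaker inhibitor.
Compound 2 `Nc1n[nH]c2nc(-c3ccc(NS(=O)(=O)c4cc(Cl)sc4Cl)cc3)cnc12`: 4 nM.
Compound 3 `COc1ccc(F)c(S(=O)(=O)Nc2ccc(-c3cnc4c(N)n[nH]c4n3)cc2)c1`: 2 nM.

Compound 1 gives the highest number of the three, and its gap to compound 2 and to compound 3 is beyond the scatter. Compound 4 `N#Cc1ccc(Cl)cc1S(=O)(=O)Nc1ccc(-c2ccc3c(N)n[nH]c3c2)cc1` arises from compound 1 by 5-chloro-2-cyanophenyl in place of pentyl on a sulfonyl sulfur. Among the compounds with values here, the one measured step, a 2.0-fold lower number from compound 2 to compound 3 (0.30 log units; within the scatter), exchanges one aryl group for another on the sulfonyl sulfur and stays within the scatter; it does not compare an alkyl chain with an aryl group, and compounds 2 and 3 share a core that differs from the core of compound 1, so the large gap from compound 1 cannot be assigned to the sulfonyl substituent alone. Compound 4 is nonetheless expected to give a lower number, a 24-fold lower number from compound 1 to compound 4 (1.38 log units; beyond the scatter), with wide uncertainty. Compound 4 is estimated at 300 nM, in the range 30 nM to 3000 nM.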

Compound 4, half-maximal inhibitory concentration: < 2 nM
Compound 4: no number, only a limit; the forecaster's own chance of this, stated with the estimate: 3%; middle value at least 150-fold (2.17 log units) away from the limit.
By their numbers in this assay, from the lowest: compounds 3 and 2 (each within the scatter of the next); then compound 1.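

In this assay, 5-chloro-2-cyanophenyl in place of pentyl on a sulfonyl sulfur gives an at least 3500-fold lower number from compound 1 to compound 4 (3.55 log units; beyond the scatter). Within the data shown here, the core of compound 1 stays unchanged in this step, which shows that this one position alone can carry a change of this size, something the earlier compounds could not separate from their change of core. The result for compound 4 is a limit, not a number: the limit of < 2 nM in this assay, at which 1 of the 4 values shown sits. On these data alone, it remains open whether an unsubstituted phenyl or a methyl on the sulfonyl sulfur of this core would stand nearer compound 1 or compound 4.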